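Predicting plasma stability after a butyl-to-cyanophenyl swap

This account rests on a few compounds, and the source may have more. Where it says the series, first, only, none or still open, it means among the compounds named here.

This account follows a series of diester prodrug analogues sharing one bicyclic core, examined in an ADME assay on a cell-free system (plasma, Homo sapiens) for metabolic stability, with Plasma (Rattus norvegicus) as the target, read by HPLC, at pH 7.4; a higher number here means that the compound lasts longer, a lower number that the compound disappears faster. Compound 1 `CCCCC(=O)O[C@@H]1CO[C@H]2[C@@H]1OC[C@@H]2OC(=O)c1ccccc1OC(C)=O` gives 0.0117 h in this assay and stands as the lowest of the three measured numbers. Compound 2 `CC(=O)Oc1ccccc1C(=O)O[C@H]1CO[C@H]2[C@@H]1OC[C@H]2OC(=O)c1ccc(C)cc1` gives 0.0362 h, and compound 3 `CC(=O)Oc1ccccc1C(=O)O[C@H]1CO[C@H]2[C@@H]1OC[C@H]2OC(=O)c1ccc([N+](=O)[O-])cc1` gives 0.0227 h. The measured steps show a 3.1-fold higher number from compound 1 to compound 2 (0.49 log units; beyond the scatter), whereas a 1.9-fold higher number from compound 1 to compound 3 (0.29 log units; within the scatter); between the two aryl esters, a 1.6-fold lower number from compound 2 to compound 3 (0.20 log units; within the scatter).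

The unmeasured compound 4 `CC(=O)Oc1ccccc1C(=O)O[C@H]1CO[C@H]2[C@@H]1OC[C@H]2OC(=O)c1ccc(C#N)cc1` differs from compound 1 by 4-cyanophenyl in place of butyl on a carbonyl carbon. Both earlier replacements of the butyl group by a substituted phenyl ring moved the half-life upward, once by a modest margin beyond the scatter and once by a margin that stays within it. A fourth aryl group of the same kind is therefore expected to behave like compounds 2 and 3 rather than like compound 1, giving a small upward step, a 2.1-fold higher number from compound 1 to compound 4 (0.33 log units; beyond the scatter), that may or may not clear the scatter. On that basis the half-life of compound 4 in this assay is estimated at 0.025 h, with a likely range from 0.012 h to 0.05 h.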

Compound 4, half-life: 0.068 h
For compound 4 the middle estimate is 2.7-fold (0.43 log units) below the measured one; measured number outside the range, above it.
By their numbers in this assay, from the lowest: compounds 1, 3, 2 and 4 (each within the scatter of the next, the first and the last beyond it).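

In this assay the exchange of butyl for 4-cyanophenyl on a carbonyl carbon gives a 5.8-fold higher number from compound 1 to compound 4 (0.76 log units; beyond the scatter) and so joins the step to compound 2 beyond the scatter, which leaves the step to compound 3 as the one aryl replacement shown that stays within it. Within the data shown here, the substituent on the aromatic ring now makes a readable difference for the first time, since cyano in place of nitro gives a 3.0-fold higher number from compound 3 to compound 4 (0.48 log units; beyond the scatter) while the earlier exchange of methyl for nitro stayed within the scatter. Cyano in place of methyl gives a 1.9-fold higher number from compound 2 to compound 4 (0.27 log units; within the scatter) so those two substituents cannot be told apart here, and nothing at hand explains the size of any of these steps.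

The compounds shown leave open how an amine or a carboxylic acid on the aromatic ring would fall among these half-lives, and whether a longer chain in place of butyl would move the number at all. They also leave open whether the ring itself or its substituent carries the larger share of the change from compound 1.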